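Pyridin-2-yl to 4-fluorophenyl: working notes on the series

This account rests on a few compounds, and the source may have more. Where it says the series, first, only, none or still open, it means among the compounds named here.

Measured in an ADME assay on Caco-2 cells (Homo sapiens) for permeability, read by LC-MS, with a stated time of 2 h, tested at 25 uM; on this read-out lower numbers stand for lower permeability and higher numbers for higher permeability:
Compound 1 `COc1cc2c(cc1OC)CN(c1ccc(C=O)cc1)CC2`: 2.8 10^-6 cm/s
Compound 2 `COc1cc2c(cc1OC)CN(c1cccnc1)CC2`: 39.5 10^-6 cm/s
Compound 3 `COc1cc2c(cc1OC)CN(c1ccccn1)CC2`: 38.8 10^-6 cm/s

Compound 3 is level with compound 2 within the scatter, and both numbers stand well above that of compound 1. Next comes compound 4 `COc1cc2c(cc1OC)CN(c1ccc(F)cc1)CC2`, with 4-fluorophenyl in place of pyridin-2-yl on an amine nitrogen in a ring. For the measured compounds named here, the only measured step that bears on it is pyridin-2-yl in place of pyridin-3-yl, a 1.0-fold lower number from compound 2 to compound 3 (0.01 log units; within the scatter), which stays within the scatter. Going by the values given here, compound 1, the only measured compound with an aromatic ring of carbon only at that place, gives 2.8 10^-6 cm/s, so the range is kept wide on the low side. The expected step in this assay is modest and downward, within the scatter: a 1.4-fold lower number from compound 3 to compound 4 (0.14 log units; within the scatter). For compound 4 the estimate is 28 10^-6 cm/s, with an expected range of 10 10^-6 cm/s to 50 10^-6 cm/s.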

Compound 4, apparent permeability in the Caco-2 assay: 20.4 10^-6 cm/s
The estimate for compound 4 lay 1.4-fold (0.14 log units) above the measured number; the range from low to high includes it.
By their numbers in the Caco-2 assay, from the lowest: compound 1; then compounds 4, 3 and 2 (each within the scatter of the next).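

In the Caco-2 assay, a ring of carbon only at this place need not give a low number: the steps are a 1.9-fold lower number from compound 3 to compound 4 (0.28 log units; within the scatter) and a 1.9-fold lower number from compound 2 to compound 4 (0.29 log units; within the scatter), whereas fluoro in place of formyl on an aromatic carbon gives a 7.3-fold higher number from compound 1 to compound 4 (0.86 log units; beyond the scatter). The low number of compound 1 therefore does not extend to every ring of carbon only on this amine nitrogen. In a physicochemical assay for lipophilicity, at pH 7.4 (on this read-out higher numbers stand for higher lipophilicity and lower numbers for lower lipophilicity), compound 3 gives 3.7 and compound 4 gives 4.5. In the physicochemical assay, the same change from pyridin-2-yl to 4-fluorophenyl does move the number beyond the scatter: the measured distribution coefficient of compound 3, 3.7, and of compound 4, 4.5, a number 0.80 log units higher (beyond the scatter)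

Open, going by these compounds, is how the Caco-2 assay responds to an amine or a carboxylic acid in place of fluoro on the aromatic ring.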